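The compounds below may be only part of what the source reports. "The series", "measured", "known", "first", "only" and "open" are said of these compounds alone.

Compound 1 `C=CC(=O)Nc1nc(-c2ccccc2)cs1`: 6600 nM
Compound 2 `C=CC(=O)N(CC(=O)OC)c1nc(-c2ccccc2)cs1`: > 30000 nM (a limit)
Compound 3 `C=CC(=O)N(CC(=O)OC(C)(C)C)c1nc(-c2ccccc2)cs1`: > 30000 nM (a limit)

These results come from a functional assay on HT-29 cells (Homo sapiens) for antiproliferative activity, read by MTT assay, with a stated time of 72 h; a higher number here means a weaker inhibitor, a lower number a stronger inhibitor. Compound 3 has no number there, only a limit, and it stands with compound 2 at the limit of > 30000 nM in this assay, at which 2 of the 3 values shown sit.

Compound 4 `C=CC(=O)N(CC(=O)NC1CCCCC1)c1nc(-c2ccccc2)cs1` is reached from compound 3 through (cyclohexylamino in place of tert-butoxy on a carbonyl carbon), that is, cyclohexylamino in place of tert-butoxy on a carbonyl carbon. Within the data shown here, no measured step makes this exchange. Among the measured compounds shown here, two steps bear on it indirectly, an at least 4.5-fold higher number from compound 1 to compound 2 (0.65 log units; beyond the scatter) and an at least 4.5-fold higher number from compound 1 to compound 3 (0.65 log units; beyond the scatter), and each puts a substituent on the amide-type nitrogen. Also on record is a step that the two limits leave unreadable from compound 2 to compound 3. Compound 4 keeps a substituent on that nitrogen, so the loss seen in an at least 4.5-fold higher number from compound 1 to compound 3 (0.65 log units; beyond the scatter) is expected to persist in this assay, with at most a small move towards a lower number. The estimated change is an at least 1.2-fold lower number from compound 3 to compound 4 (0.07 log units; that floor lies within the scatter). For compound 4 the expected half-maximal inhibitory concentration is 25000 nM, with an estimated range of 8000 nM to 60000 nM.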

Compound 4, half-maximal inhibitory concentration: > 30000 nM
Compound 4 gave a limit, no number (the forecaster's own chance of this, stated with the estimate: 55%); at least 1.2-fold (0.07 log units) between middle value and limit.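

In this assay, among these compounds, compound 4 gives > 30000 nM as a limit and not a number, so no step from compound 2 or compound 3 to compound 4 can be read: the limit of > 30000 nM in this assay, at which 3 of the 4 values shown sit. The compounds shown leave open whether any substituent on the amide-type nitrogen retains the activity of compound 1.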